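The source may report more compounds than this note shows. Statements on the series, on what has been measured and on what is new or still open speak of the compounds shown alone.

Measured compounds in an ADME assay on HeLa cells (Homo sapiens) for cytotoxicity, read by sulforhodamine B assay, with a stated time of 48 h, tested at 10 uM; a higher number here means more inhibition at the concentration tested (going by the name of the read-out), a lower number less inhibition:

- compound 1 `COc1nc2ccc(Br)cc2cc1C(c1ccccc1)n1cc(-c2ccc(Br)cc2)nn1` gives 6.92%
- compound 2 `CCCCCCCc1cn(C(c2ccccc2)c2cc3cc(Br)ccc3nc2OC)nn1` gives 9.7%
- compound 3 `COc1nc2ccc(Br)cc2cc1C(c1ccccc1)n1cc(-c2cccc(F)c2)nn1` gives 9.04%

Compound 1 stands lowest of the three numbers, but only nominally so: its nearest neighbour is compound 3 at a number 2.1 percentage points higher from compound 1 to compound 3 (within the scatter) and its furthest is compound 2 at a number 2.8 percentage points higher from compound 1 to compound 2 (within the scatter), both within the scatter, so the three measured compounds cannot be told apart in this assay.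

Compound 4 `CCCCCCCCc1cn(C(c2ccccc2)c2cc3cc(Br)ccc3nc2OC)nn1` has not yet been measured. It differs from compound 1 in one place: octyl in place of 4-bromophenyl on an aromatic carbon. Going by the values given here, the step that bears most directly on this change is the one from compound 1 to compound 2, where heptyl replaced 4-bromophenyl on the same aromatic carbon and gave a number 2.8 percentage points higher from compound 1 to compound 2 (within the scatter). Octyl is the same kind of chain, one carbon longer, and the step from compound 2 to compound 3, a number 0.7 percentage points lower from compound 2 to compound 3 (within the scatter), shows that swapping an aryl group for a chain at this position moves nothing beyond the scatter either. No step beyond the scatter is therefore expected for compound 4 in this assay.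

Compound 4 is accordingly estimated at 9.5%, with a range from 2% to 18%, which means an expected step of a number 2.6 percentage points higher from compound 1 to compound 4 (within the scatter) from compound 1.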

Compound 4, a percentage reported as inhibition, at one concentration (the size of the read-out at that concentration, not a potency): 0.1%
Estimate against measurement, compound 4: 9.4 percentage points above; measured number below the stated range.
By their numbers in this assay, from the lowest: compounds 4, 1, 3 and 2 (each within the scatter of the next).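

In this assay, octyl on this aromatic carbon adds a further replacement for 4-bromophenyl, and all three of its steps stay within the scatter: a number 6.8 percentage points lower from compound 1 to compound 4 (within the scatter), a number 8.9 percentage points lower from compound 3 to compound 4 (within the scatter) and, for the one added methyl on the saturated chain, a number 9.6 percentage points lower from compound 2 to compound 4 (within the scatter). With compound 4 included, the aryl and chain groups at this position still cannot be told apart, and the one-carbon lengthening of the chain shows no readable effect. Nothing measured here explains where these numbers fall.

The compounds shown leave open whether any group at this position can move the number beyond the scatter, as they carry only aryl groups and plain chains. From the compounds shown here alone, an amine or a carboxylic acid on the chain, or a much longer chain such as dodecyl, remains untested among them.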